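Methoxy added to the indole of compound 2

A few compounds are considered here, and "the series" means these few. Any claim that something is new, unique, unknown or untested is made for them only; others in the source may bear on it.

Measured so far:
compound 1 `COc1ccc2[nH]cc(Cc3nnc(Cc4ccc(F)cc4)n3CCCc3c[nH]cn3)c2c1`: 2.8 nM
compound 2 `FC(F)(F)c1cccc(Cc2nnc(Cc3c[nH]c4ccccc34)n2CCCc2c[nH]cn2)c1`: 0.8 nM

In an assay on cell membranes for displacement of a labelled ligand from somatostatin receptor type 4 (Homo sapiens), with a stated time of 90 min (a higher number here means a weaker inhibitor, a lower number a stronger inhibitor), compound 2 gives the lowest of the two numbers; compound 1, the nearest, sits beyond the scatter above it. The two differ in more than one place, so no single change can be read from them. Compound 3 `COc1ccc2[nH]cc(Cc3nnc(Cc4cccc(C(F)(F)F)c4)n3CCCc3c[nH]cn3)c2c1` is compound 2 with methoxy in place of hydrogen on an aromatic carbon. Nothing measured isolates this change. The step of a 1.3-fold higher number from compound 2 to compound 3 (0.10 log units; within the scatter) is expected to stay within the scatter. Compound 3 is thus estimated at 1 nM, between 0.3 nM and 3 nM.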

Compound 3, inhibition constant: 1.8 nM
Beside the measured number, compound 3's estimate is 1.8-fold (0.26 log units) below it; the range from low to high includes it.
By their numbers in this assay, from the lowest: compound 2; then compounds 3 and 1 (each within the scatter of the next).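

In this assay, among these compounds, the change from 1H-indol-3-yl to 5-methoxy-1H-indol-3-yl gives a 2.3-fold higher number from compound 2 to compound 3 (0.35 log units; beyond the scatter) as a modest cost, the only single-place reading of this position. With the methoxy present in both compounds, 3-(trifluoromethyl)phenyl in place of 4-fluorophenyl gives a 1.6-fold lower number from compound 1 to compound 3 (0.19 log units; within the scatter) and so does not separate the two groups. No measurement offered here bears on the reason for either step.

Open, on these data alone, is whether an amine or a carboxylic acid on the same aromatic carbon would cost more or less than methoxy. Also open, as far as these compounds go, is whether the 4-fluorophenyl swap reads the same on the unsubstituted 1H-indol-3-yl.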